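The source may report more compounds than this note shows. Statements on the series, on what has been measured and on what is new or still open speak of the compounds shown alone.

Values in a functional assay on NCI-H929 cells (Homo sapiens) for antiproliferative activity, with a stated time of 24 h; on this read-out higher numbers stand for weaker inhibition and lower numbers for stronger inhibition:
- compound 1 `COc1ccc(F)cc1-c1ccnc2[nH]c(C3=CCC(C(=O)O)CC3)cc12`: 1200 nM
- compound 2 `COc1ccc(F)cc1-c1ccnc2[nH]c(C3=CCN([C@H]4CC[C@H](C(=O)O)CC4)CC3)cc12`: 110 nM
- compound 3 `COc1ccc(F)cc1-c1c(F)cnc2[nH]c(C3=CCN([C@H]4CC[C@H](C(=O)O)CC4)CC3)cc12`: 40 nM

Compound 3 gives the lowest number of the three, and its gaps to compound 1 and compound 2 lie beyond the scatter. The next compound is compound 4 `COc1ccc(F)cc1-c1c(F)cnc2[nH]c(C3=CCN([C@H]4CC[C@H](CC(=O)O)CC4)CC3)cc12`, with this change: carboxymethyl in place of carboxy on a saturated ring carbon. Among the compounds with values here, the only measured single-place step, a 2.8-fold lower number from compound 2 to compound 3 (0.44 log units; beyond the scatter), is modest and is a fluoro in place of hydrogen on an aromatic carbon, not a change at the carboxy group. Within the data shown here, it therefore gives only weak guidance, and no measured step isolates this change. In this assay, a small rise is tentatively expected, probably not beyond the scatter. The expected step is a 1.4-fold higher number from compound 3 to compound 4 (0.14 log units; within the scatter). For compound 4 the estimate is 55 nM, with an expected range of 18 nM to 170 nM.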

Compound 4, half-maximal inhibitory concentration: 60 nM
Compound 4: the middle estimate sits 1.1-fold (0.04 log units) below what was measured; measured number inside the range.
By their numbers in this assay, from the lowest: compounds 3, 4 and 2 (each within the scatter of the next, the first and the last beyond it); then compound 1.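

In this assay the change from 4-carboxycyclohexyl to 4-(carboxymethyl)cyclohexyl gives a 1.5-fold higher number from compound 3 to compound 4 (0.18 log units; within the scatter) at this saturated ring carbon. Within the data shown here, the acid group can therefore sit one carbon further out without a step beyond the scatter, which the earlier compounds, none of which varied this group, did not show. No measurement at hand explains this result. Still open, on these data alone, are a longer chain ending in a carboxylic acid and the replacement of the acid on this ring carbon by an amide or an amine.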